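A few compounds are considered here, and "the series" means these few. Any claim that something is new, unique, unknown or untested is made for them only; others in the source may bear on it.

Working notes on the hydrazone series.

Three measured analogues share one core and a hydrazone arm ending in a substituted phenyl. Compound 1 `O=C(CCc1nc2ccccc2c(=O)[nH]1)N/N=C/c1ccc(Cl)cc1` carries a chloro on that phenyl; in a physicochemical assay, read by spectrophotometry, with a stated time of 6 min (a higher number here means a weaker inhibitor, a lower number a stronger inhibitor), compound 1 gives 185000000 nM. Compound 2 `O=C(CCc1nc2ccccc2c(=O)[nH]1)N/N=C/c1ccc([N+](=O)[O-])cc1` carries a nitro instead, and in this assay compound 2 gives 220000000 nM; the step of a 1.2-fold higher number from compound 1 to compound 2 (0.08 log units; within the scatter). Compound 3 `O=C(CCCc1nc2ccccc2c(=O)[nH]1)N/N=C/c1ccc([N+](=O)[O-])cc1` keeps the nitrophenyl and differs from compound 2 only in the linker between the core and the hydrazide; in this assay compound 3 gives 270000000 nM. Compound 3 thus returns the largest of the three numbers, but its gaps to compound 2 and to compound 1 both fall within the scatter, so the three are not separated.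

Compound 4 `O=C(CCCc1nc2ccccc2c(=O)[nH]1)N/N=C/c1cc(O)c(O)c(O)c1` is the next analogue; it differs from compound 3 by 3,4,5-trihydroxyphenyl in place of 4-nitrophenyl on a carbon with a double bond to nitrogen. Going by the values given here, the only measured step on the same phenyl, a 1.2-fold higher number from compound 1 to compound 2 (0.08 log units; within the scatter), swapped one group without hydrogen-bond donors for another and stayed within the scatter. The present change is larger than any measured one, since the entering group brings hydrogen-bond donors the series has not yet carried, so the expectation rests on little. Compound 4 is expected to give about 120000000 nM, within 20000000 nM to 400000000 nM. That estimate means a step of a 2.3-fold lower number from compound 3 to compound 4 (0.35 log units; beyond the scatter), leaning to a lower number but not firmly beyond the scatter.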

Compound 4, half-maximal inhibitory concentration: 40000000 nM
Estimate against measurement, compound 4: 3.0-fold (0.48 log units) above; the measured number falls inside the stated range.
By their numbers in this assay, from the lowest: compound 4; then compounds 1, 2 and 3 (each within the scatter of the next).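

In this assay the exchange of 4-nitrophenyl for 3,4,5-trihydroxyphenyl on the carbon with a double bond to nitrogen gives a 6.8-fold lower number from compound 3 to compound 4 (0.83 log units; beyond the scatter) and is the first listed step in the series to lie beyond the scatter. The earlier exchange on this phenyl, nitro in place of chloro, gave a 1.2-fold higher number from compound 1 to compound 2 (0.08 log units; within the scatter) and stayed within the scatter, so it is this pair that first shows the number responding to what the phenyl carries, here with an entering group that has hydrogen-bond donors and a leaving group that has none. This remains the reading of a single pair, and no measurement shown accounts for the step.

The compounds shown leave open whether the lower number requires all three hydroxy groups, or whether a single hydroxy group or three methoxy groups on the phenyl would give a similar step. As far as these compounds go, it is also open whether the same exchange would give a step of similar size on the linker of compound 2, which differs from the linker of compound 3.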